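The source may report more compounds than this note shows. Statements on the series, on what has been measured and on what is new or still open speak of the compounds shown alone.

Measured so far:
compound 1 `Oc1cccc(-c2cc(-c3cccc(C(F)(F)F)c3)cc(-c3ccccc3O)n2)c1` — 6340 nM
compound 2 `Oc1cccc(-c2cc(-c3cccc(C(F)(F)F)c3)cc(-c3cccc(O)c3)n2)c1` — 4970 nM

Within the data shown here, in a functional assay on T47D cells (Homo sapiens) for inhibition (on this read-out higher numbers stand for weaker inhibition and lower numbers for stronger inhibition), compound 1 gives 6340 nM, the higher of the two numbers measured so far; its nearest neighbour is compound 2, which gives 4970 nM. Among the measured compounds shown here, the one measured step, a 1.3-fold lower number from compound 1 to compound 2 (0.11 log units; within the scatter), swaps 3-hydroxyphenyl for 2-hydroxyphenyl on an aromatic carbon and does not leave the scatter, so the two compounds cannot be placed in order on this read-out.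

Compound 3 `Oc1cccc(-c2cc(-c3cccc(OC(F)(F)F)c3)cc(-c3ccccc3O)n2)c1` is the next candidate. It differs from compound 1 in one place only: trifluoromethoxy in place of trifluoromethyl on an aromatic carbon. No measured step touches this part of the molecule, so there is nothing among the shown pairs that bears directly on the change. For the measured compounds named here, the only measured step concerns a different group and was itself within the scatter, which gives no ground for expecting a move in either direction. Compound 3 is therefore expected to sit close to compound 1, with an estimated step of a 1.1-fold lower number from compound 1 to compound 3 (0.02 log units; within the scatter). The estimate for compound 3 in this assay is 6000 nM, within a range from 2500 nM to 15000 nM.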

Compound 3, half-maximal inhibitory concentration: 5390 nM
Compound 3: the middle estimate sits 1.1-fold (0.05 log units) above what was measured; the range from low to high includes it.
By their numbers in this assay, from the lowest: compounds 2, 3 and 1 (each within the scatter of the next).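

Among these compounds, the swap of trifluoromethyl for trifluoromethoxy, on an aromatic carbon of a six-membered aromatic ring of carbon only and meta to a large group, gives the only measured step at this position in (this assay): (a 1.2-fold lower number from compound 1 to compound 3 (0.07 log units; within the scatter)). One added oxygen and one added hydrogen-bond acceptor at this place therefore leave compound 3 and compound 1 inseparable on this read-out, and the step at the hydroxyphenyl group (a 1.3-fold lower number from compound 1 to compound 2 (0.11 log units; within the scatter)) likewise stays inside the scatter, so neither of the two places has yet moved the number measurably. No measurement shown here offers an explanation for the size of this step.

On these data alone, with only these two fluorinated groups compared at this position, it remains open whether a quite different substituent, such as an amine, a carboxylic acid or a longer alkyl chain, would shift the number beyond the scatter. As far as these compounds go, it is equally open whether removing either hydroxyl group from the core of compound 1, or replacing it with a methoxy group, would change the reading.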